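This account rests on a few compounds, and the source may have more. Where it says the series, first, only, none or still open, it means among the compounds named here.

Measured compounds:
Compound 1, `CN(C)c1ccc2c(=O)c(C(=O)Nc3cc(F)cc(F)c3)cn(-c3ccc(Cl)c(OCCCCCCC[N+]45CCN(CC4)CC5)c3)c2n1`, with 8.08%.
Compound 2, `CN1CC[N+](C)(CCCCCCCOc2cc(-n3cc(C(=O)Nc4cc(F)cc(F)c4)c(=O)c4ccc(N(C)C)nc43)ccc2Cl)CC1`, with 27.5%.

Both were tested in an assay on LX2 cells for inhibition of COL1A1 promoter (Homo sapiens), read by a luciferase reporter, with a stated time of 24 h, tested at 20 uM; a higher number here means a stronger effect of the compound at the concentration tested, a lower number a weaker effect. Compound 2 stands highest of the two, and its nearest neighbour, compound 1, sits a clear step lower: a number 19.4 percentage points higher from compound 1 to compound 2 (beyond the scatter). Among the measured compounds shown here, that single step is the only measured change at the charged end of the chain, and it shows that exchanging one charged head group for another can move the read-out by a modest amount.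

Compound 3, `CN(C)c1ccc2c(=O)c(C(=O)Nc3cc(F)cc(F)c3)cn(-c3ccc(Cl)c(OCCCCCCC[N+](C)(C)C4CCCCC4)c3)c2n1`, has not yet been measured. It differs from compound 2 at the same place: a group of 9 heavy atoms (8 carbon, 1 nitrogen; one six-membered non-aromatic ring of carbon only) in place of a group of 8 heavy atoms (6 carbon, 2 nitrogen; one six-membered non-aromatic ring with 2 hetero atoms), on a saturated chain carbon, seven bonds along the chain from an oxygen on an aromatic ring. For the measured compounds named here, only the step from compound 1 to compound 2 bears on this change, and it was modest in size, so a shift of similar magnitude in either direction, or none beyond the scatter, is plausible. With a single precedent the direction cannot be called with confidence.

Compound 3 is therefore expected to land near compound 2, at about 25%, within a range from 5% to 50%. The expected step from compound 2 to compound 3 is a number 2.5 percentage points lower from compound 2 to compound 3 (within the scatter).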

Compound 3, a percentage reported as inhibition, at one concentration (the size of the read-out at that concentration, not a potency): 37.6%
The estimate for compound 3 lay 12.6 percentage points below the measured number; measured number inside the range.
By their numbers in this assay, from the lowest: compound 1; then compound 2; then compound 3.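

The new result shows that this position still has room to move upward: with the six-membered ring of carbon only, this assay gives a number 10.1 percentage points higher from compound 2 to compound 3 (beyond the scatter). The leaving and entering groups both carry a net charge of +1, so at this saturated chain carbon the read-out changes even though the net charge of the group does not; the entering group has 0 hydrogen-bond acceptors where the leaving group has 1, and the two also differ in ring content and heavy-atom count, so these compounds cannot show which of these differences matters. The wider comparison gives a number 29.5 percentage points higher from compound 1 to compound 3 (beyond the scatter), which places compound 3 highest of the three, though no measurement is available to explain this order.

From the compounds shown here alone, what remains open is whether the carbon ring itself is needed, or whether a simple trimethylammonium end or a piperidine ring would serve as well. Also open, going by these compounds, is how a phenyl ring on the charged nitrogen, or a longer chain carrying the same cyclohexyl dimethylammonium group, would compare at this single tested concentration.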